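This account rests on a few compounds, and the source may have more. Where it says the series, first, only, none or still open, it means among the compounds named here.

Measured so far:
Compound 1, `COc1ccc(/C=C2\NS(=O)(=O)c3ccccc3C2=O)cc1`, in an assay for inhibition of alkaline phosphatase, tissue-nonspecific isozyme (Homo sapiens), read by spectrophotometry, with stated times of 10 min and 20 min (on this read-out lower numbers stand for stronger inhibition and higher numbers for weaker inhibition), gives 4040 nM.
Compound 2, `O=C1/C(=C/c2ccc(Br)cc2)NS(=O)(=O)c2ccccc21`, in this assay gives 1430 nM.

Among the compounds with values here, compound 2 stands at the lower of the two numbers; its only neighbour is compound 1, separated by a 2.8-fold lower number from compound 1 to compound 2 (0.45 log units; beyond the scatter). That step, bromo in place of methoxy on an aromatic carbon, is the only one measured in the series.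

Compound 3, `O=C1/C(=C/c2ccc(F)cc2)NS(=O)(=O)c2ccccc21`, differs from compound 2 by fluoro in place of bromo on an aromatic carbon, para to a large group. Within the data shown here, no measured step exchanges bromo for fluoro, so the step from compound 1 to compound 2 is only an indirect guide: it shows that a change at this place can move the number in this assay by a modest amount. For compound 3 the expected step is a 1.7-fold higher number from compound 2 to compound 3 (0.24 log units; within the scatter), a drift toward a higher number that may well remain within the scatter. Compound 3 is therefore estimated at 2500 nM in this assay, with a range of 1000 nM to 6500 nM.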

Compound 3, half-maximal inhibitory concentration: 1350 nM
Estimate against measurement, compound 3: 1.9-fold (0.27 log units) above; low and high end bracket the measured number.
By their numbers in this assay, from the lowest: compounds 3 and 2 (each within the scatter of the next); then compound 1.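

In this assay the exchange of one halogen for another at this position reads a 1.1-fold lower number from compound 2 to compound 3 (0.03 log units; within the scatter) and leaves 4-bromophenyl and 4-fluorophenyl without a difference that can be read here. Fluoro in place of methoxy reads a 3.0-fold lower number from compound 1 to compound 3 (0.48 log units; beyond the scatter) and so gives a second halogen that stands apart from compound 1, which means the earlier separation was not peculiar to bromo among the compounds shown. No measured evidence accounts for either step.

Still open, from the compounds shown here alone, is whether the separation from compound 1 follows from the presence of a halogen or from the absence of methoxy, since chloro or an unsubstituted phenyl at this position would help to tell these apart. Also open, going by these compounds, is how an amine, a carboxylic acid or a longer alkyl chain at this position would read, as would any change on the shared core.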